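Urea terminus: pyridinyl to ethyl, microsomal half-life

The source may report more compounds than this note shows. Statements on the series, on what has been measured and on what is new or still open speak of the compounds shown alone.

Compound 2 `O=C(Nc1ccc(-c2nc(N3CC4CCC(C3)O4)c3cnn(C4CCC5(CC4)OCCO5)c3n2)cc1)Nc1cccnc1` sits level with compound 1 `O=C(Nc1ccccc1)Nc1ccc(-c2nc(N3CC4CCC(C3)O4)c3cnn(C4CCC5(CC4)OCCO5)c3n2)cc1` in an in vitro ADME assay on microsomes (Homo sapiens) for metabolic stability; on this read-out lower numbers stand for a shorter-lived compound and higher numbers for a longer-lived compound: compound 2 gives 0.217 h and compound 1 gives 0.217 h. For the measured compounds named here, the single measured step, no change at the digits printed from compound 1 to compound 2 (within the scatter), lies within the scatter. Compound 3 `CCNC(=O)Nc1ccc(-c2nc(N3CC4CCC(C3)O4)c3cnn(C4CCC5(CC4)OCCO5)c3n2)cc1` is the next member; it differs from compound 2 by ethyl in place of pyridin-3-yl on an amide-type nitrogen. Going by the values given here, the one known step replaces phenyl with pyridin-3-yl on the same amide-type nitrogen, whereas the new change leaves no ring there, so that step bears on it only loosely. Among the compounds with values here, with no measured step pointing in either direction, no shift beyond the scatter is expected, a 1.0-fold higher number from compound 2 to compound 3 (0.01 log units; within the scatter). Compound 3 is estimated at 0.22 h, between 0.1 h and 0.5 h.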

Compound 3, half-life: 0.167 h
For compound 3 the middle estimate is 1.3-fold (0.12 log units) above the measured one; the range from low to high includes it.
By their numbers in this assay, from the lowest: compounds 3, 1 and 2 (each within the scatter of the next).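

Taking the ring off the amide-type nitrogen altogether stays within the scatter in this assay, with ethyl in place of pyridin-3-yl giving a 1.3-fold lower number from compound 2 to compound 3 (0.11 log units; within the scatter) and ethyl in place of phenyl giving a 1.3-fold lower number from compound 1 to compound 3 (0.11 log units; within the scatter). At this position, the three termini shown are therefore not separated by this read-out, whether aromatic ring or ethyl. Nothing available explains this result. Open, going by these compounds, is whether any group on this nitrogen moves the half-life beyond the scatter. A longer chain, a carboxylic acid or an amine carried on the ethyl would address that.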